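Spiro-piperidine to pyridinyl-piperazine swap on the shared core

A few compounds are considered here, and "the series" means these few. Any claim that something is new, unique, unknown or untested is made for them only; others in the source may bear on it.

Measured compounds in a physicochemical assay for solubility, read by spectrophotometry, in phosphate buffer, with a stated time of 2 h, at pH 7.4; a lower number here means a less soluble compound, a higher number a more soluble compound:
compound 1 `COc1ccc2[nH]c(C(=O)N3CC(=O)N(Cc4ccccc4)[C@@H](CN4CCC5(CC4)CC5)C3)cc2c1` — 28200 nM
compound 2 `COc1ccc2[nH]c(C(=O)N3CC(=O)N(Cc4cccc(OC(F)F)c4)[C@@H](CN4CCC(C#N)CC4)C3)cc2c1` — 27900 nM
compound 3 `COc1ccc2[nH]c(C(=O)N3CC(=O)N(c4ccccc4)[C@@H](Cc4ccccc4)C3)cc2c1` — 36100 nM

Compound 1 cannot be separated from the other two on these numbers: the value of compound 2 is within the scatter of it, and the value of compound 3, the one furthest from it, is also within the scatter. Going by the values given here, the three compounds differ in more than one place, so no single step between measured compounds is available to lean on, and the three values together simply describe a narrow band in this assay.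

Compound 4 `COc1ccc2[nH]c(C(=O)N3CC(=O)N(Cc4ccccc4)[C@@H](CN4CCN(c5ccccn5)CC4)C3)cc2c1` is built from compound 1 by one change: a group of 12 heavy atoms (9 carbon, 3 nitrogen; one six-membered non-aromatic ring with 2 hetero atoms, one six-membered aromatic ring with 1 hetero atom) in place of a group of 8 heavy atoms (7 carbon, 1 nitrogen; one three-membered non-aromatic ring of carbon only, one six-membered non-aromatic ring with 1 hetero atom), on a saturated chain carbon bound to a saturated ring carbon. Among the compounds with values here, nothing among the measured compounds isolates this kind of exchange, so no measured step can be used to size it. The expectation is a step from compound 1 to compound 4 of a 1.2-fold lower number from compound 1 to compound 4 (0.07 log units; within the scatter), that is, nothing beyond the scatter in either direction, with a slight lean toward a lower number given that all three measured values cluster closely and give no sign of a move upward. Compound 4 is estimated at 24000 nM in this assay, with a range from 9000 nM to 50000 nM.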

Compound 4, solubility: 30200 nM
For compound 4 the middle estimate is 1.3-fold (0.10 log units) below the measured one, within the range that was stated.
By their numbers in this assay, from the lowest: compounds 2, 1, 4 and 3 (each within the scatter of the next).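

In this assay, going by these compounds alone, the group 4-(pyridin-2-yl)piperazin-1-yl, in place of the group carrying a three-membered ring of carbon only and a six-membered non-aromatic ring, on a saturated chain carbon bound to a saturated ring carbon, gives a 1.1-fold higher number from compound 1 to compound 4 (0.03 log units; within the scatter) as the first step that isolates one place. The earlier compounds shown here differed in more than one place, whereas this pair shows that, at this position, a group of 12 heavy atoms with 3 hydrogen-bond acceptors and one of 8 heavy atoms with 1 hydrogen-bond acceptor cannot be told apart in this assay on the shared core. No measurement shown here offers a reason for this reading.

Within the data shown here, the series still holds only this one step at this position, so a single exchange says nothing about whether a simple dimethylamino group, a piperazine with a carboxylic acid on its outer nitrogen, or a phenyl ring in place of the pyridine would also stay within the scatter of compound 1. On these data alone, whether the same exchange reads alike with a different group on the ring nitrogen of the shared core, such as the 3-(difluoromethoxy)benzyl group of compound 2, also remains open.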